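This account rests on a few compounds, and the source may have more. Where it says the series, first, only, none or still open, it means among the compounds named here.

Working notes on the series. Compound 1 `O=C(NNc1ccc(F)cc1)c1ccccc1NS(=O)(=O)c1cnc(O)nc1O` is the starting point. In a functional assay on OVCAR-3 cells (Homo sapiens) for antiproliferative activity, read by MTT assay, with a stated time of 24 h (a higher number here means a weaker inhibitor, a lower number a stronger inhibitor), compound 1 gives only a limit, > 20000 nM, so its true value is not known and it sits at the limit of > 20000 nM in this assay, at which 1 of the 2 values shown sits, rather than at a number. Compound 2 `O=C(NNC(=O)c1ccccc1Cl)c1ccc(NS(=O)(=O)c2cnc(O)nc2O)cc1` is the other measured member; in this assay compound 2 gives 5220 nM. Going by the values given here, no single-change step connects compound 1 and compound 2, so their two values show only that one member of the series returns a measurable number while the other does not.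

Compound 3 `O=C(NNC(=O)c1ccccc1NS(=O)(=O)c1cnc(O)nc1O)c1ccccc1F` remains to be measured. It differs from compound 1 in one place: (2-fluorophenyl)carbonyl in place of 4-fluorophenyl on an amine nitrogen. Among the compounds with values here, no measured pair reproduces this change, so its size has to be guessed. Since compound 1 stands at the limit of > 20000 nM in this assay, at which 1 of the 2 values shown sits, any gain would first have to bring compound 3 inside the measurable window; a modest gain in that direction is expected, though a further limit is also plausible. The step of an at least 1.6-fold lower number from compound 1 to compound 3 (0.22 log units; that floor lies within the scatter) is the size expected here. For compound 3 the estimate is 12000 nM, with a range from 4000 nM to 40000 nM.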

Compound 3, half-maximal inhibitory concentration: 15300 nM
Estimate against measurement, compound 3: 1.3-fold (0.11 log units) below, within the range that was stated.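

The change from 4-fluorophenyl to (2-fluorophenyl)carbonyl on an amine nitrogen whose other neighbour is an amide-type nitrogen gives a measured number at this position: in this assay compound 3 gives 15300 nM. The change reads as an at least 1.3-fold lower number from compound 1 to compound 3 (0.11 log units; that floor lies within the scatter), so this single step gives a floor only, and that floor does not separate the two groups from the usual scatter. Compound 1 remains a limit, so the true size of the step stays unknown: the limit of > 20000 nM in this assay, at which 1 of the 3 values shown sits.

This change brings in a carbonyl and alters the name of the fluorophenyl group at once, so the compounds shown do not tell which of the two goes with the measurable value; (4-fluorophenyl)carbonyl at the same place would separate them. Also open, from the compounds shown here alone, is how the number would respond to other groups on this amine nitrogen, such as an unsubstituted benzoyl group, a carboxylic acid or a longer alkyl chain.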